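The source may hold more compounds than are shown below. What is called first, only, known or untested is meant among the compounds shown, and "the series" means these compounds.

Three compounds share one core and differ only in the group carried on the aniline ring. Compound 1 `O=C(/C=C\Nc1ccc(F)cc1)c1cn(-c2ccccc2)nc1-c1ccc(Cl)cc1` gives 17900 nM in a functional assay on U-87MG ATCC cells (Homo sapiens) for antiproliferative activity, read by MTT assay, with a stated time of 48 h; a higher number here means a weaker inhibitor, a lower number a stronger inhibitor. Compound 2 `O=C(/C=C\Nc1ccc(Cl)cc1)c1cn(-c2ccccc2)nc1-c1ccc(Cl)cc1` gives 13100 nM in this assay, and the change of chloro in place of fluoro on an aromatic carbon gives a 1.4-fold lower number from compound 1 to compound 2 (0.14 log units; within the scatter). For compound 3 `O=C(/C=C\Nc1ccc(C(F)(F)F)cc1)c1cn(-c2ccccc2)nc1-c1ccc(Cl)cc1` the read-out is a limit of the assay, not a number: > 50000 nM. Compound 3 therefore sits at the limit of > 50000 nM in this assay, at which 1 of the 3 values shown sits. From compound 1, trifluoromethyl in place of fluoro gives an at least 2.7-fold higher number from compound 1 to compound 3 (0.44 log units; beyond the scatter), and from compound 2, trifluoromethyl in place of chloro gives an at least 3.8-fold higher number from compound 2 to compound 3 (0.58 log units; beyond the scatter).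

Compound 4 `COc1cc(-c2nn(-c3ccccc3)cc2C(=O)/C=C\Nc2ccc(C(F)(F)F)cc2)cc(OC)c1OC` differs from compound 3 at another place: 3,4,5-trimethoxyphenyl in place of 4-chlorophenyl on an aromatic carbon. For the measured compounds named here, none of the measured steps touches this place, so none gives a size for it. Going by the values given here, with compound 3 standing at the limit and no step to lean on, compound 4 is estimated at 30000 nM, within a wide range from 5000 nM to 100000 nM, which would mean an expected step of an at least 1.6-fold lower number from compound 3 to compound 4 (0.22 log units; that floor lies within the scatter).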

Compound 4, half-maximal inhibitory concentration: > 50000 nM
Compound 4 gave a limit, no number; the forecaster's own chance of this, stated with the estimate: 45%; middle value at least 1.6-fold (0.22 log units) away from the limit.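

Compound 3 and compound 4 both stand at a limit of the assay rather than at a number, so the step between them cannot be read: the limit of > 50000 nM in this assay, at which 2 of the 4 values shown sit.

From the compounds shown here alone, what 3,4,5-trimethoxyphenyl in place of 4-chlorophenyl does to the read-out remains open, both here and alongside the fluoro and chloro groups of compound 1 and compound 2.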